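The compounds below may be only part of what the source reports. "The series", "measured", "known", "first", "only" and "open" are said of these compounds alone.

Values in a functional assay on A549 cells (Homo sapiens) for antiproliferative activity, read by MTT assay, with a stated time of 48 h; a higher number here means a weaker inhibitor, a lower number a stronger inhibitor:
- compound 1 `C=C(c1cc(OC)c(OC)c(OC)c1)c1ccc(OC)c(O)c1NC(=O)COC`: 190 nM
- compound 2 `C=C(c1cc(OC)c(OC)c(OC)c1)c1ccc(OC)c(O)c1NC(=O)COCC`: 880 nM
- compound 3 `C=C(c1cc(OC)c(OC)c(OC)c1)c1ccc(OC)c(O)c1NC(=O)CO`: not yet measured

Compound 2 holds the higher of the two numbers. The next change, ethoxy to hydroxy, is hydrogen in place of ethyl on an oxygen on a saturated carbon. Among the compounds with values here, only one measured step bears on it: a 4.6-fold higher number from compound 1 to compound 2 (0.67 log units; beyond the scatter) on lengthening that chain, modest but beyond the scatter. Within the data shown here, removing the ethyl is therefore expected to lower the number by a similar size, although no hydroxy compound has been measured yet. The expected change is a 3.1-fold lower number from compound 2 to compound 3 (0.50 log units; beyond the scatter) in this series. Compound 3 is estimated at 280 nM (80 nM to 1000 nM).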

Compound 3, half-maximal inhibitory concentration: 10 nM
The estimate for compound 3 lay 28-fold (1.45 log units) above the measured number; the whole stated range lies above it.
By their numbers in this assay, from the lowest: compound 3; then compound 1; then compound 2.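

In this assay, the free hydroxy gives an 88-fold lower number from compound 2 to compound 3 (1.94 log units; beyond the scatter) and also a 19-fold lower number from compound 1 to compound 3 (1.28 log units; beyond the scatter) in this series. Both steps are larger than a 4.6-fold higher number from compound 1 to compound 2 (0.67 log units; beyond the scatter) on lengthening the chain, so most of the span at this oxygen lies between hydrogen and either alkyl group, not between methyl and ethyl. Nothing available explains the size of this step.

From the compounds shown here alone, whether an amine or a carboxylic acid in place of the hydroxy keeps the low number remains open. So does whether a longer chain on this oxygen raises the number further.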